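This account rests on a few compounds, and the source may have more. Where it says the series, first, only, none or still open, it means among the compounds named here.

In a toxicity assay on HepG2 2.2.15 cells (Homo sapiens) for cytotoxicity, read by CellTiter-Glo (a higher number here means that more compound is tolerated, a lower number that less compound is tolerated), compound 3 `O=C1CC(c2ccccc2)CN1c1cnn2c1CN(C(=O)Nc1cc(F)c(F)c(F)c1)C(Cc1ccccc1)C2` gives > 2000 nM, which is a limit and not a number. Compound 4 `O=C1CC(c2ccccc2)CN1c1cnn2c1CN(C(=O)Nc1cc(F)c(F)c(F)c1)C(C1CC1)C2` differs from it in one place: cyclopropyl in place of benzyl on a saturated ring carbon. Within the data shown here, no measured step makes this exchange. The closest guide comes from two compounds that already carry cyclopropyl: compound 1 `O=C(Nc1cc(F)c(F)c(F)c1)N1Cc2c(-c3ccc(F)cc3F)cnn2CC1C1CC1` gives 32100 nM and compound 2 `O=C1NC(c2ccccc2)CN1c1cnn2c1CN(C(=O)Nc1cc(F)c(F)c(F)c1)C(C1CC1)C2` gives 38500 nM. Among the measured compounds shown here, their one measured step, a 1.2-fold higher number from compound 1 to compound 2 (0.08 log units; within the scatter), exchanges a different group on an aromatic carbon and stays within the scatter. Compound 4 is therefore expected to lie close to these two. Going by these compounds, the expected step is a step that the limit leaves unreadable from compound 3 to compound 4, towards more compound tolerated, but its true size is unknown. The estimate for compound 4 is 30000 nM, with an expected range from 12000 nM to 70000 nM.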

Compound 4, half-maximal cytotoxic concentration: 12800 nM
For compound 4 the middle estimate is 2.3-fold (0.37 log units) above the measured one; measured number inside the range.
By their numbers in this assay, from the lowest: compound 4; then compounds 1 and 2 (each within the scatter of the next).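

With cyclopropyl held on the saturated ring carbon, the group on the aromatic carbon can shift tolerance in this assay. Placing 2-oxo-4-phenylpyrrolidin-1-yl there gives a 3.0-fold lower number from compound 2 to compound 4 (0.48 log units; beyond the scatter), and also a 2.5-fold lower number from compound 1 to compound 4 (0.40 log units; beyond the scatter), whereas the earlier exchange at this carbon stayed within the scatter. The benzyl-to-cyclopropyl step itself cannot be read, because compound 3 carries only a limit: the limit of > 2000 nM in this assay, at which 1 of the 4 values shown sits.

Going by these compounds, how far benzyl and cyclopropyl truly differ therefore stays open. So does what a methyl group or an amine on that saturated ring carbon would give in this assay.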